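Dichlorophenyl imine: expected cytotoxicity of compound 4

A few compounds are considered here, and "the series" means these few. Any claim that something is new, unique, unknown or untested is made for them only; others in the source may bear on it.

Measured compounds:
Compound 1 `Cc1c(/N=C/c2cccc(O)c2)c(=O)n(-c2ccccc2)n1C` gives 166000000 nM in a functional assay on HT-29 cells (Homo sapiens) for cytotoxicity, read by MTT assay, with a stated time of 72 h; on this read-out lower numbers stand for stronger inhibition and higher numbers for weaker inhibition.
Compound 2 `Cc1c(/N=C/c2ccccc2Cl)c(=O)n(-c2ccccc2)n1C` gives 309000000 nM.
Compound 3 `Cc1c(/N=C/c2ccccc2)c(=O)n(-c2ccccc2)n1C` gives 851000000 nM.

Compound 3 stands at the highest of the three numbers, separated from the others by a 2.8-fold higher number from compound 2 to compound 3 (0.44 log units; beyond the scatter) and a 5.1-fold higher number from compound 1 to compound 3 (0.71 log units; beyond the scatter). Compound 4 `Cc1c(/N=C/c2ccc(Cl)cc2Cl)c(=O)n(-c2ccccc2)n1C` differs from compound 3 by 2,4-dichlorophenyl in place of phenyl on a carbon with a double bond to nitrogen. The step that bears on this is the chloro change, a 2.8-fold higher number from compound 2 to compound 3 (0.44 log units; beyond the scatter), which went in the weakening direction on removing the chloro; a 1.9-fold higher number from compound 1 to compound 2 (0.27 log units; within the scatter) shows the two substituted aryl rings close together. Among the compounds with values here, the second chloro has no measured counterpart, so its contribution is unknown. A modest lowering is expected, a 3.9-fold lower number from compound 3 to compound 4 (0.59 log units; beyond the scatter). Compound 4 is therefore estimated at 220000000 nM, range 80000000 nM to 600000000 nM, because a 2.8-fold higher number from compound 2 to compound 3 (0.44 log units; beyond the scatter) ran the other way.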

Compound 4, half-maximal inhibitory concentration: 178000000 nM
Beside the measured number, compound 4's estimate is 1.2-fold (0.09 log units) above it, and the stated range covers the measured number.
By their numbers in this assay, from the lowest: compounds 1, 4 and 2 (each within the scatter of the next); then compound 3.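

On a carbon with a double bond to nitrogen, 2,4-dichlorophenyl in place of phenyl moves the number clearly (a 4.8-fold lower number from compound 3 to compound 4 (0.68 log units; beyond the scatter)), so the substituted rings stay apart from phenyl. The added chloro (a 1.7-fold lower number from compound 2 to compound 4 (0.24 log units; within the scatter)) and the exchange of 3-hydroxyphenyl for 2,4-dichlorophenyl (a 1.1-fold higher number from compound 1 to compound 4 (0.03 log units; within the scatter)) do not separate the substituted compounds from one another. No evidence on the cause of these steps is at hand.

On these data alone, whether an amine, a carboxylic acid or a methoxy group on this ring would move the number further remains open.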